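A few compounds are considered here, and "the series" means these few. Any claim that something is new, unique, unknown or untested is made for them only; others in the source may bear on it.

Measured so far:
Compound 2 `O=C(CSc1nccn1-c1cccc2ccccc12)Nc1ccccc1F`: 34700 nM
Compound 1 `O=C(CSc1nccn1-c1ccc(Cl)cc1)Nc1ccccc1[N+](=O)[O-]`: > 321000 nM
Compound 3 `COc1ccc(-n2ccnc2SCC(=O)Nc2ccccc2Cl)cc1`: > 334000 nM

Three compounds were run in an ADME assay on MT4 cells (Homo sapiens) for cytotoxicity, read by MTT assay; a lower number here means that less compound is tolerated, a higher number that more compound is tolerated. For the measured compounds named here, compound 2 gives 34700 nM in this assay, and it is the only actual number among the three values shown. For compound 1 the result is a limit of the assay, > 321000 nM, as recorded in the limit of > 321000 nM in this assay, at which 1 of the 3 values shown sits. For compound 3 the result is likewise a limit, > 334000 nM, as recorded in the limit of > 334000 nM in this assay, at which 1 of the 3 values shown sits. Going by the values given here, the pairs involving compound 1 or compound 3 therefore show only that compound 2 gives a number where the other two give limits; no measured step connects any two of them.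

Compound 4 `Cc1ccccc1NC(=O)CSc1nccn1-c1cccc2ccccc12` differs from compound 2 by methyl in place of fluoro on an aromatic carbon, the rest of the molecule unchanged. Among the compounds with values here, no measured step touches this position, so there is no precedent within the set. Given a change of one heavy atom for one heavy atom, the expectation is a step that stays within the usual scatter, with no particular direction. Compound 4 is accordingly estimated at 35000 nM, with a range from 15000 nM to 90000 nM. The expected step is a 1.0-fold higher number from compound 2 to compound 4 (0.00 log units; within the scatter).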

Compound 4, half-maximal cytotoxic concentration: 34600 nM
The estimate for compound 4 lay 1.0-fold (0.00 log units) above the measured number; the range from low to high includes it.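

In this assay the set now holds its first measured step, methyl in place of fluoro on an aromatic carbon, ortho to a large group, and that step reads a 1.0-fold lower number from compound 2 to compound 4 (0.00 log units; within the scatter) and lies within the scatter. Where the earlier compounds offered one number and two limits, compound 2 and compound 4 give two actual numbers for molecules that differ in one place only, and in this read-out 2-fluorophenyl and 2-methylphenyl cannot be told apart with the rest of the molecule unchanged. For the compounds shown here, the only further information available concerns the limits of other compounds, and it says nothing about why this pair reads as it does.

The compounds shown leave open how this place responds to a group larger than a single heavy atom or to one of another kind, such as a methoxy group, an amine or a carboxylic acid. They also leave open whether methyl in place of fluoro would read the same way on a different core, such as that of compound 1 or compound 3, whose results are limits.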